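The source may report more compounds than this note shows. Statements on the series, on what has been measured and on what is new or still open speak of the compounds shown alone.

Compound 1, with the structure `Fc1ccc(C2=NN(c3nc(-c4ccccc4)cs3)C(c3cccs3)C2)cc1`, is the starting point here. In a functional assay on WM 266-4 cells (Homo sapiens) for antiproliferative activity, read by MTT assay, with a stated time of 48 h (a lower number here means a stronger inhibitor, a higher number a weaker inhibitor), compound 1 gives 170 nM. Compound 2, the structure `Fc1ccc(C2=NN(c3nc(-c4ccc(C(F)(F)F)cc4)cs3)C(c3cccs3)C2)cc1`, differs from compound 1 by one change: trifluoromethyl in place of hydrogen on an aromatic carbon. In this assay compound 2 gives 5120 nM, so the step is a 30-fold higher number from compound 1 to compound 2 (1.48 log units; beyond the scatter). Compound 3, the structure `Brc1ccc(C2=NN(c3nc(-c4ccccc4)cs3)C(c3cccs3)C2)cc1`, carries a different core, and the two cores differ by bromo in place of fluoro on an aromatic carbon. In this assay compound 3 gives 1870 nM, a step of an 11-fold higher number from compound 1 to compound 3 (1.04 log units; beyond the scatter).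

Compound 4, the structure `FC(F)(F)c1ccc(-c2csc(N3N=C(c4ccc(Br)cc4)CC3c3cccs3)n2)cc1`, has not yet been measured in this assay. It stands to compound 3 as compound 2 stands to compound 1, through the same change: trifluoromethyl in place of hydrogen on an aromatic carbon. The place of the change reads the same word for word in both pairs. Among the measured compounds shown here, the only guide to what this change does is the single measured step from compound 1 to compound 2, which was large, and whether it repeats on the core of compound 3 is not known. The step from compound 3 to compound 4 is therefore expected to be of a similar kind, roughly a 21-fold higher number from compound 3 to compound 4 (1.33 log units; beyond the scatter), resting on a 30-fold higher number from compound 1 to compound 2 (1.48 log units; beyond the scatter). On that basis compound 4 is expected to give about 40000 nM in this assay, with a range from 10000 nM to 150000 nM.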

Compound 4, half-maximal inhibitory concentration: 27400 nM
Compound 4: middle estimate off by 1.5-fold (0.16 log units), on the high side; low and high end bracket the measured number.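

In this assay, the change from phenyl to 4-(trifluoromethyl)phenyl gives a 15-fold higher number from compound 3 to compound 4 (1.17 log units; beyond the scatter), so it is again a large loss of activity, and the step on the core of compound 3 agrees with the one on the core of compound 1: the same change on two cores in this assay, a 30-fold higher number (1.48 log units; beyond the scatter) from compound 1 to compound 2 and a 15-fold higher number (1.17 log units; beyond the scatter) from compound 3 to compound 4, 2.1-fold (0.31 log units) apart, within the scatter of two such steps The second change, bromo in place of fluoro, gives a 5.4-fold higher number from compound 2 to compound 4 (0.73 log units; beyond the scatter), and this too matches its earlier step: the same change on two cores in this assay, an 11-fold higher number (1.04 log units; beyond the scatter) from compound 1 to compound 3 and a 5.4-fold higher number (0.73 log units; beyond the scatter) from compound 2 to compound 4, 2.1-fold (0.31 log units) apart, within the scatter of two such steps Together, these four compounds show that each change went the same way and by a comparable size on both cores, so the two steps could be carried from one core to the other here, but two pairs per change in one cell assay do not show that this holds for other cores, and they do not explain why either change weakens activity.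

The compounds shown leave open what other groups would do at the place of the trifluoromethyl, such as a methyl, a methoxy group or an amine. They also leave open whether chloro in place of fluoro would follow the step seen with bromo.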